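The source may hold more compounds than are shown below. What is called first, only, known or untested is meant among the compounds shown, and "the series" means these compounds.

The measured compounds, with their values in a functional assay on A549 cells (Homo sapiens) for antiproliferative activity, read by MTT assay, with a stated time of 72 h; on this read-out higher numbers stand for weaker inhibition and lower numbers for stronger inhibition:

Compound 1 `CCC/C=C/C(=O)Nc1cc2c(N3CCc4ccccc43)ncnc2cc1OC`: 2920 nM
Compound 2 `COc1cc2ncnc(N3CCCc4ccccc43)c2cc1NC(=O)C=C(C)C`: 5410 nM
Compound 3 `CCC/C=C/C(=O)Nc1cc2c(N3CCCc4ccccc43)ncnc2cc1OC`: 1800 nM

Compound 3 gives the lowest of the three numbers in this assay. Its nearest neighbour is compound 1, and the step of a 1.6-fold lower number from compound 1 to compound 3 (0.21 log units; within the scatter) stays within the scatter, so no order between those two can be read. The step of a 3.0-fold lower number from compound 2 to compound 3 (0.48 log units; beyond the scatter) lies beyond the scatter, and it is this change on the carbonyl carbon, from 2-methylprop-1-en-1-yl to pent-1-en-1-yl, that separates compound 3 from compound 2.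

Compound 4 `COc1cc2ncnc(N3CCCc4ccccc43)c2cc1NC(=O)/C=C/CN1CCCC1` keeps the core of compound 3 and alters the same acyl chain once more: pyrrolidin-1-yl in place of ethyl on a saturated chain carbon bound to a double-bonded chain carbon. For the measured compounds named here, of the two measured steps, only the one from compound 2 to compound 3 touches this part of the molecule, and it was modest. Going by the values given here, there is no measured example of a ring entering the chain at this place, so the expectation leans on that single modest step alone. A modest improvement, or none beyond the scatter, is the likely outcome; the step of a 2.0-fold lower number from compound 3 to compound 4 (0.30 log units; within the scatter) is the estimated change from compound 3. Compound 4 is therefore expected to give about 900 nM in this assay, with a range from 300 nM to 3000 nM.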

Compound 4, half-maximal inhibitory concentration: 2230 nM
Beside the measured number, compound 4's estimate is 2.5-fold (0.39 log units) below it, and the stated range covers the measured number.
By their numbers in this assay, from the lowest: compounds 3, 4, 1 and 2 (each within the scatter of the next, the first and the last beyond it).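

In this assay, the step of a 1.2-fold higher number from compound 3 to compound 4 (0.09 log units; within the scatter) stays within the scatter, so at this saturated chain carbon bound to a double-bonded chain carbon, pyrrolidin-1-yl, with its five heavy atoms, ring and hydrogen-bond acceptor, gives a number that cannot be told apart from that of ethyl, which has two heavy atoms and neither feature. The step of a 2.4-fold lower number from compound 2 to compound 4 (0.38 log units; beyond the scatter) lies beyond the scatter but is modest, and the step of a 3.0-fold lower number from compound 2 to compound 3 (0.48 log units; beyond the scatter) is of the same kind, so in these three compounds both pent-1-en-1-yl and 3-(pyrrolidin-1-yl)prop-1-en-1-yl on the carbonyl carbon give lower numbers than 2-methylprop-1-en-1-yl. No other measurement is at hand that could account for these numbers.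

What the compounds shown leave open is whether this tolerance extends to other amines at the same place, such as piperidin-1-yl, morpholin-4-yl or dimethylamino, or to a carboxylic acid or a longer chain. They also leave open whether pyrrolidin-1-yl behaves the same way on the core of compound 1, which carries 2,3-dihydro-1H-indol-1-yl.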